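Replacing the iodo group with hydrogen on the sulfonamide

The source may report more compounds than this note shows. Statements on the series, on what has been measured and on what is new or still open speak of the compounds shown alone.

In a functional assay on HT-29 cells (Homo sapiens) for antiproliferative activity, read by sulforhodamine B assay, with a stated time of 48 h (on this read-out lower numbers stand for stronger inhibition and higher numbers for weaker inhibition), compound 1 `O=C1NCCN1c1ccc(S(=O)(=O)Nc2ccc(C3CCCCC3)cc2)cc1` gives > 1000 nM, which is a limit and not a number. Within the data shown here, compound 2 `O=C1NCCN1c1ccc(S(=O)(=O)Nc2ccc(I)cc2)cc1` gives 650 nM, the only actual number so far. Iodo in place of cyclohexyl on an aromatic carbon gives an at least 1.5-fold lower number from compound 1 to compound 2 (0.18 log units; that floor lies within the scatter). Compound 3 `O=C1NCCN1c1ccc(S(=O)(=O)Nc2ccccc2)cc1` carries one further change, (hydrogen in place of iodo on an aromatic carbon), hydrogen in place of iodo on an aromatic carbon. Among the measured compounds shown here, no measured step tests this exchange directly, so the step to compound 2 an at least 1.5-fold lower number from compound 1 to compound 2 (0.18 log units; that floor lies within the scatter) offers only a loose guide to what this position tolerates. A modest rise in the number is expected in this assay, with the expected step being a 2.3-fold higher number from compound 2 to compound 3 (0.36 log units; beyond the scatter). Compound 3 may well end at the limit of > 1000 nM in this assay, at which 1 of the 2 values shown sits. For compound 3 the estimated value is 1500 nM, with an expected range from 500 nM to 5000 nM.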

Compound 3, half-maximal inhibitory concentration: 280 nM
Compound 3: middle estimate off by 5.4-fold (0.73 log units), on the high side, outside the stated range (below it).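

Taking the substituent away altogether costs nothing at this position: in this assay, going from 4-iodophenyl to phenyl gives a 2.3-fold lower number from compound 2 to compound 3 (0.37 log units; beyond the scatter), so the iodo group is not needed for activity here. The earlier step from cyclohexyl to iodo had a floor within the scatter, whereas an at least 3.5-fold lower number from compound 1 to compound 3 (0.55 log units; beyond the scatter) clears it and shows that hydrogen at this place gives a lower number than cyclohexyl. Compound 1 remains a limit and not a number: the limit of > 1000 nM in this assay, at which 1 of the 3 values shown sits.

With only hydrogen, iodo and cyclohexyl at this place, the compounds shown leave open whether a small group such as fluoro, methyl or methoxy would lower the number further or raise it again. From the compounds shown here alone, how an amine or a carboxylic acid would fare at this place also stays open.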